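This account rests on a few compounds, and the source may have more. Where it says the series, first, only, none or still open, it means among the compounds named here.

Four related compounds are compared in an ADME assay on MRC5 cells (Homo sapiens), read by MTT assay, with a stated time of 72 h; on this read-out lower numbers stand for stronger inhibition and higher numbers for weaker inhibition. Compound 1 `COc1ncnc2c1c(-c1ccsc1)cn2[C@@H]1O[C@H](CO)[C@@H](O)[C@H]1O` gives 75300 nM in this assay. Compound 2 `CN(C)c1ncnc2c1c(-c1ccsc1)cn2[C@@H]1O[C@H](CO)[C@@H](O)[C@H]1O` differs from compound 1 in a single group, (methoxy in place of dimethylamino on an aromatic carbon). For compound 2 this assay reports only a limit, > 100000 nM. The step of an at least 1.3-fold lower number from compound 2 to compound 1 (0.12 log units; that floor lies within the scatter) therefore rests on that limit and stays small. Compound 3 `CN(C)c1ncnc2c1c(-c1cc3ccccc3o1)cn2[C@@H]1O[C@H](CO)[C@@H](O)[C@H]1O` carries a different core than compound 2, and the two cores differ as follows: 1-benzofuran-2-yl in place of thiophen-3-yl on an aromatic carbon. For compound 3 the read-out is again only a limit, > 100000 nM. The step that the two limits leave unreadable from compound 2 to compound 3 cannot be read because both values sit at the limit of > 100000 nM in this assay, at which 2 of the 3 values shown sit.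

Compound 4 `COc1ncnc2c1c(-c1cc3ccccc3o1)cn2[C@@H]1O[C@H](CO)[C@@H](O)[C@H]1O` has not yet been measured. It arises from compound 3 by the same change that leads from compound 2 to compound 1: methoxy in place of dimethylamino on an aromatic carbon. Given that the earlier step of an at least 1.3-fold lower number from compound 2 to compound 1 (0.12 log units; that floor lies within the scatter) stayed within the usual scatter, the estimated step this time is an at least 1.1-fold lower number from compound 3 to compound 4 (0.04 log units; that floor lies within the scatter). Compound 4 is thus expected to give about 90000 nM, with a likely range from 45000 nM to 200000 nM, and a fair chance that this assay again reports only a limit.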

Compound 4, half-maximal inhibitory concentration: 65600 nM
Compound 4: middle estimate off by 1.4-fold (0.14 log units), on the high side; measured number inside the range.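

In this assay, methoxy in place of dimethylamino on the core carrying 1-benzofuran-2-yl gives an at least 1.5-fold lower number from compound 3 to compound 4 (0.18 log units; that floor lies within the scatter), a step that rests on the limit reported for compound 3. The same change on the core carrying thiophen-3-yl gives a step of the same kind, so the result fits with the change carrying over, but it does not show that the change has a real effect on either core or the same effect on both: the same change on two cores in this assay, an at least 1.3-fold lower number (0.12 log units; that floor lies within the scatter) from compound 2 to compound 1 and an at least 1.5-fold lower number (0.18 log units; that floor lies within the scatter) from compound 3 to compound 4; the limit leaves it open whether they differ. Among the methoxy compounds, the swap of thiophen-3-yl for 1-benzofuran-2-yl gives a 1.1-fold lower number from compound 1 to compound 4 (0.06 log units; within the scatter), while the matching step between the dimethylamino compounds cannot be read: the limit of > 100000 nM in this assay, at which 2 of the 4 values shown sit.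

The compounds shown leave open whether another group on this aromatic carbon, such as a primary amine, ethoxy or a longer chain, would move the number beyond the usual scatter. They also leave open whether the methoxy step would hold on a core bearing a group other than these two, such as phenyl.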